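Swapping the aniline ring on a pyrimidine acyltransferase inhibitor

A few compounds are considered here, and "the series" means these few. Any claim that something is new, unique, unknown or untested is made for them only; others in the source may bear on it.

Compound 1 `Nc1nc(Nc2ccc(Cl)cc2)cc(-c2cc(Cl)ccc2O)n1` and compound 2 `CCOc1ccc(Cl)cc1-c1cc(Nc2ccc(Cl)cc2)nc(N)n1` share a core and differ only at one oxygen. In an assay on Sf9 cells for inhibition of 1-acyl-sn-glycerol-3-phosphate acyltransferase beta (Homo sapiens) (a higher number here means a weaker inhibitor, a lower number a stronger inhibitor), compound 1 gives 10000 nM, while compound 2 gives 17 nM. That single change, ethyl in place of hydrogen on an oxygen on an aromatic ring, produced a 590-fold lower number from compound 1 to compound 2 (2.77 log units; beyond the scatter). Among the compounds with values here, compound 2 therefore holds the lowest number of the two measured, with compound 1 the only neighbour and far behind it.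

Compound 3 `CCOc1ccc(Cl)cc1-c1cc(Nc2cccc([N+](=O)[O-])c2)nc(N)n1` keeps the ethyl on oxygen from compound 2 and alters the other end of the molecule instead: 3-nitrophenyl in place of 4-chlorophenyl on a nitrogen on an aromatic ring. Within the data shown here, no measured step touches this position, since the only step recorded concerns the oxygen. The data thus give no direct guide to the size or direction of the change, and the expectation is a modest movement, most likely toward a higher number, that may well fall within the scatter. Compound 3 is expected to give about 50 nM, with a range from 10 nM to 300 nM. The estimated step in this assay is a 2.9-fold higher number from compound 2 to compound 3 (0.47 log units; beyond the scatter).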

Compound 3, half-maximal inhibitory concentration: 640 nM
Estimate against measurement, compound 3: 13-fold (1.11 log units) below; measured number outside the range, above it.
By their numbers in this assay, from the lowest: compound 2; then compound 3; then compound 1.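

Within the data shown here, the ring on the nitrogen, which no earlier step touched, turns out to matter a great deal in this assay: 3-nitrophenyl in place of 4-chlorophenyl gives a 38-fold higher number from compound 2 to compound 3 (1.58 log units; beyond the scatter). The ethyl on the oxygen is therefore not enough on its own to secure a low number, since compound 3 keeps that ethyl and still gives 640 nM, so both ends of the molecule move the result. No measurement at hand accounts for this rise, and its reason stays unknown.

This single swap changes both the group on the ring and the numbering of its place, so the two compounds cannot show which of those differences carries the loss, or whether 4-chlorophenyl is especially favourable or 3-nitrophenyl especially poor. Also open, from the compounds shown here alone, is how the number would respond to a plain phenyl ring, or to a phenyl ring bearing an amine, a methoxy group or a carboxylic acid, on the same nitrogen with the ethyl on the oxygen kept in place.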